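The source may report more compounds than this note shows. Statements on the series, on what has been measured and on what is new or still open speak of the compounds shown alone.

Among the compounds with values here, the two measured members were run in a functional assay on HOS-TE85 cells (Homo sapiens) for inhibition, read by CCK-8 assay, with a stated time of 72 h, tested at 1 uM; on this read-out lower numbers stand for less inhibition and higher numbers for more inhibition at the one concentration tested (going by the name of the read-out). Compound 1 `COc1ccccc1N1C(=O)CSC1C(=O)NCCCCc1ccccc1` gives the lower result: in this assay compound 1 gives 0%. Compound 2 `COc1ccc(F)cc1N1C(=O)CSC1c1cccc(C(=O)NCCCCc2ccccc2)c1` stands highest of the two numbers; in this assay compound 2 gives 95%, a result that lies beyond the scatter above compound 1. Compound 3 `COc1cc(F)ccc1N1C(=O)CSC1c1cccc(C(=O)NCCCCc2ccccc2)c1` is not yet measured in this assay. It differs from compound 2 in one place: 4-fluoro-2-methoxyphenyl in place of 5-fluoro-2-methoxyphenyl on an amide-type nitrogen in a ring. The two compounds have the same atoms, joined differently, so the change is only a rearrangement of the group on the amide-type nitrogen in a ring. Because compound 2 gives 95%, compound 3 is expected to stay near that level, with the step from compound 2 to compound 3 estimated at a number 10 percentage points lower from compound 2 to compound 3 (within the scatter), likely within the scatter. For compound 3 the estimated value in this assay is 85%, between 55% and 98%.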

Compound 3, a percentage reported as inhibition, at one concentration (the size of the read-out at that concentration, not a potency): 94%
Compound 3: the middle estimate sits 9 percentage points below what was measured; low and high end bracket the measured number.
By their numbers in this assay, from the lowest: compound 1; then compounds 3 and 2 (each within the scatter of the next).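

In this assay, 4-fluoro-2-methoxyphenyl in place of 5-fluoro-2-methoxyphenyl on the amide-type nitrogen in a ring gives a number 1 percentage points lower from compound 2 to compound 3 (within the scatter). Within the data shown here, this is the first pair that differs in one place, and it shows that, at this one concentration, the read-out does not tell these two fluorine placements apart, so the rearrangement of this group leaves the high level in place. Nothing measured here offers an explanation for this result.

The compounds shown leave open whether this level holds when the fluorine gives way to a chlorine or an amine, or when the methoxy group gives way to a hydroxyl group. They also leave open whether compound 2 and compound 3 would still match at lower concentrations, which a single-concentration read-out cannot show.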